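A few compounds are considered here, and "the series" means these few. Any claim that something is new, unique, unknown or untested is made for them only; others in the source may bear on it.

Measured in a functional assay on PC-3 cells (Homo sapiens) for cytotoxicity, read by MTT assay, with a stated time of 48 h; on this read-out higher numbers stand for weaker inhibition and lower numbers for stronger inhibition:

Compound 1 `COc1ccc(/C=C/C(=O)/C=C/c2cc3ccccc3nc2Cl)cc1`: > 10000 nM
Compound 2 `COc1ccc(/C=C/C(=O)/C=C/c2cc3ccccc3nc2Cl)c(OC)c1`: > 10000 nM

Compound 2 gives > 10000 nM, which is a limit of the assay and not a number. Compound 1 gives > 10000 nM, which is also a limit. Taken together, the record so far is the limit of > 10000 nM in this assay, at which 2 of the 2 values shown sit.

Compound 3 `COc1cc(OC)c(OC)cc1/C=C/C(=O)/C=C/c1cc2ccccc2nc1Cl` carries one further change to compound 2: methoxy in place of hydrogen on an aromatic carbon. This is a methoxy in place of hydrogen on an aromatic carbon.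

Within the data shown here, the only measured step of the same kind is a step that the two limits leave unreadable from compound 1 to compound 2. It offers no size to carry over, so no step beyond the usual scatter is expected in this assay, in either direction. The expected change is a step that the limit leaves unreadable from compound 2 to compound 3. Compound 3 is estimated at 15000 nM, with an expected range of 6000 nM to 40000 nM, and it may well be reported only as a limit.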

Compound 3, half-maximal inhibitory concentration: 3120 nM
Compound 3: the middle estimate sits 4.8-fold (0.68 log units) above what was measured; the whole stated range lies above it.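

In this assay, the added methoxy gives an at least 3.2-fold lower number from compound 2 to compound 3 (0.50 log units; beyond the scatter), a change beyond the usual scatter towards stronger inhibition, while the earlier methoxy step from compound 1 to compound 2 cannot be read. This shows that a methoxy at this position, ortho to a methoxy group, para to a methoxy group and meta to a large group, can move the result measurably. Compound 3 is the only compound shown that gives a number, and the others stop at the same limit of the assay: the limit of > 10000 nM in this assay, at which 2 of the 3 values shown sit.

Going by these compounds, the true size of the step stays open, as only its smallest possible size can be read. Also open, on these data alone, is whether this methoxy would have the same effect without the other methoxy groups, and whether a hydroxyl, an amine or a longer ethoxy group at this position would match it.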